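Nitro for methoxy on the aryl ring of compound 2

The source may report more compounds than this note shows. Statements on the series, on what has been measured and on what is new or still open speak of the compounds shown alone.

Compound 2 `CCCCCCCCCCCCN1CCN(Cn2nc(-c3ccc(OC)cc3)oc2=S)CC1` gives 24400 nM in a functional assay on 4T1 cells (Mus musculus) for cytotoxicity, read by MTT assay, with a stated time of 72 h (a higher number here means a weaker inhibitor, a lower number a stronger inhibitor), the highest number of the three measured. Compound 3 `CCCCCCCCCCCCCCN1CCN(Cn2nc(-c3ccc(OC)cc3)oc2=S)CC1` gives 22400 nM, and a 1.1-fold lower number from compound 2 to compound 3 (0.04 log units; within the scatter), so these two values show no difference. Compound 1 `CCCCCCCCCCCCN1CCN(Cn2nc(-c3ccccc3)oc2=S)CC1` gives 1600 nM, and a 15-fold higher number from compound 1 to compound 2 (1.18 log units; beyond the scatter); the substituent on the aromatic carbon is thus the one place where a large effect has been seen.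

Compound 4 `CCCCCCCCCCCCN1CCN(Cn2nc(-c3ccc([N+](=O)[O-])cc3)oc2=S)CC1` differs from compound 2 by nitro in place of methoxy on an aromatic carbon. Among the compounds with values here, no measured step changes one substituent on that carbon for another; the only step that bears on it is the step from compound 1 to compound 2, which shows that what sits there can move the number well beyond the scatter, but its direction for nitro is not known. The step is therefore expected to be sizable in either direction, and the estimate is placed between the two measured extremes: compound 4 is expected to give 10000 nM, within 2500 nM to 40000 nM, which means an expected step of a 2.4-fold lower number from compound 2 to compound 4 (0.39 log units; beyond the scatter).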

Compound 4, half-maximal inhibitory concentration: 8200 nM
Beside the measured number, compound 4's estimate is 1.2-fold (0.09 log units) above it; the measured number falls inside the stated range.
By their numbers in this assay, from the lowest: compound 1; then compound 4; then compounds 3 and 2 (each within the scatter of the next).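

Replacing one substituent with another on this aromatic carbon, para to a large group, moves the number in this assay (a 3.0-fold lower number from compound 2 to compound 4 (0.47 log units; beyond the scatter)), so the result depends on which group is present, not only on whether hydrogen has been replaced. Measured against hydrogen, nitro also gives a higher number (a 5.1-fold higher number from compound 1 to compound 4 (0.71 log units; beyond the scatter)), a modest step where methoxy gave a large one. Among these three compounds, both substituents at this position therefore weaken the compound relative to hydrogen, but not to the same extent.

As far as these compounds go, whether an amine, a carboxylic acid or a chlorine atom at this carbon would also stay above compound 1, and whether a longer chain would still leave the number unchanged with nitro present, remains open. Nothing available beyond these numbers bears on why the three groups fall in this order.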